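Compound 3 to compound 4: one aromatic ring for another

The source may hold more compounds than are shown below. What is called first, only, known or untested is meant among the compounds shown, and "the series" means these compounds.

Of the compounds shown here, three on a shared core have been measured so far in an ADME assay on microsomes from liver (Rattus norvegicus) for metabolic stability (a higher number here means that the compound lasts longer, a lower number that the compound disappears faster), on this series. Compound 1 `CC(C)C(c1ccc(-c2ccc3cccc(F)c3c2)[nH]c1=O)N1CCCCC1=O` gives 0.102 h there, and compound 2 `CC(C)C(c1ccc(-c2ccc3cccc(F)c3c2)[nH]c1=O)N1CCN/C1=N\C#N` gives 0.327 h in the same read-out, which amounts to a 3.2-fold higher number from compound 1 to compound 2 (0.51 log units; beyond the scatter) in all. Compound 3 `CC(C)C(Cc1noc(=O)[nH]1)c1ccc(-c2ccc3cccc(F)c3c2)[nH]c1=O` gives > 3 h as a limit of the assay and not as a number. Compound 3 thus stands at the limit of > 3 h in this assay, at which 1 of the 3 values shown sits, in this series.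

Compound 4 `CC(C)C(Cc1nnn[nH]1)c1ccc(-c2ccc3cccc(F)c3c2)[nH]c1=O` has not yet been measured. Its difference from compound 3 is a group of 5 heavy atoms (1 carbon, 4 nitrogen; one five-membered aromatic ring with 4 hetero atoms) in place of a group of 6 heavy atoms (2 carbon, 2 nitrogen, 2 oxygen; one five-membered aromatic ring with 3 hetero atoms), on a saturated chain carbon, two bonds along the chain from an aromatic carbon in one place. The exchange brings in 1H-tetrazol-5-yl, and both groups are five-membered aromatic rings with no net charge. Within the data shown here, the steps that bear on it most are an at least 29-fold higher number from compound 1 to compound 3 (1.46 log units; beyond the scatter) and an at least 9.1-fold higher number from compound 2 to compound 3 (0.96 log units; beyond the scatter), both beyond the scatter, and each puts an aromatic ring where a non-aromatic one stood. The present exchange keeps an aromatic ring, so no step beyond the scatter is expected in this assay for compound 4. The estimated change is a step that the limit leaves unreadable from compound 3 to compound 4 in this read-out. For compound 4 the expected value is 4 h with an estimated range from 1.5 h to 10 h in the same read-out.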

Compound 4, half-life: 2.08 h
The estimate for compound 4 lay 1.9-fold (0.28 log units) above the measured number, within the range that was stated.
By their numbers in this assay, from the lowest: compound 1; then compound 2; then compound 4. At a limit, above all of these: compound 3.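

In this assay compound 4 gives 2.08 h, a real number rather than a limit, for a five-membered aromatic ring on this saturated chain carbon. With 1H-tetrazol-5-yl in this place, the series shows a 20-fold higher number from compound 1 to compound 4 (1.31 log units; beyond the scatter) and a 6.4-fold higher number from compound 2 to compound 4 (0.80 log units; beyond the scatter), both beyond the scatter, so the rise over the two compounds with non-aromatic rings no longer rests on a limit alone. The exchange of one aromatic ring for another gives an at least 1.4-fold lower number from compound 3 to compound 4 (0.15 log units; that floor lies within the scatter), which is only a floor, and the true size of this step cannot be read: the limit of > 3 h in this assay, at which 1 of the 4 values shown sits.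

The compounds shown leave open whether an aromatic ring is needed here at all, a question that a carboxylic acid or an open-chain amide in this place could address. They also leave open whether the higher numbers extend to other five-membered aromatic rings, such as a triazole or an oxadiazole without the carbonyl, and whether a longer chain carrying 1H-tetrazol-5-yl would keep them.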